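The source may hold more compounds than are shown below. What is called first, only, known or untested is meant among the compounds shown, and "the series" means these compounds.

For the measured compounds named here, compound 2 `C=C(Br)C(=O)Nc1ccc2c(c1)/C(=C\c1cccs1)C(=O)N2` is one of three compounds measured in a functional assay on HeLa cells (Homo sapiens) for antiproliferative activity, read by MTT assay, with a stated time of 72 h; on this read-out higher numbers stand for weaker inhibition and lower numbers for stronger inhibition. In this assay compound 2 gives 1800 nM, the second highest of the three numbers. Going by the values given here, compound 1 `C=C(Br)C(=O)Nc1ccc2c(c1)/C(=C/c1cccs1)C(=O)N2` gives 1700 nM in this assay; the step of a 1.1-fold higher number from compound 1 to compound 2 (0.02 log units; within the scatter) is the only one-place comparison measured so far, and it lies within the scatter, which fits (the fact that compounds 1 and 2 differ only in the configuration as drawn). Compound 3 `C#CC(=O)Nc1ccc2c(c1)/C(=C/c1ccc[nH]1)C(=O)N2` gives 4400 nM in this assay; compound 3 differs from compound 2 in more than one place, so the two values are only set side by side: compound 3 has the higher number, and the gap is beyond the scatter.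

Compound 4 `C=C(Br)C(=O)Nc1ccc2c(c1)/C(=C\c1sccc1C)C(=O)N2` is not yet measured. It differs from compound 2 by methyl in place of hydrogen on an aromatic carbon, that is thiophen-2-yl to 3-methylthiophen-2-yl. Among the compounds with values here, no measured step concerns a substituent on this ring; the one measured step concerns configuration alone and is within the scatter. No direction can be drawn from the measured pairs, so no step beyond the scatter is expected in this assay. The step is estimated as no change at the digits printed from compound 2 to compound 4 (within the scatter). Within the data shown here, for compound 4 the expected value in this assay is 1800 nM, with a range from 700 nM to 4500 nM, the width reflecting that no measured step bears on this change.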

Compound 4, half-maximal inhibitory concentration: 450 nM
Beside the measured number, compound 4's estimate is 4.0-fold (0.60 log units) above it; the measured number lies below the stated range.
By their numbers in this assay, from the lowest: compound 4; then compounds 1 and 2 (each within the scatter of the next); then compound 3.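

Methyl on this aromatic carbon, next to the ring atom that bears a large group and two ring bonds from the ring sulfur, is the first change in the series to move the number beyond the scatter: in this assay, thiophen-2-yl to 3-methylthiophen-2-yl gives a 4.0-fold lower number from compound 2 to compound 4 (0.60 log units; beyond the scatter). The only earlier one-place comparison, a 1.1-fold higher number from compound 1 to compound 2 (0.02 log units; within the scatter), concerned configuration alone and said nothing about substitution on this ring, so this position is now shown to respond, with the lower number standing for stronger inhibition. Nothing at hand bears on why a single methyl produces this step.

Going by these compounds, it remains open whether a longer chain such as ethyl, or a methoxy group, a chlorine atom or an amine in this same place, would lower the number further, hold it or raise it, and whether methyl elsewhere on this ring would act alike. On these data alone, it is also open whether the step carries over to the opposite double-bond configuration of compound 1 or to the alkynyl amide and nitrogen-containing ring of compound 3.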